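The compounds below may be only part of what the source reports. "The series", "measured", "known", "first", "only" and "open" are said of these compounds alone.

Going by the values given here, compound 2 `COc1cc(Nc2nc(SCc3ccc(C(F)(F)F)cc3)nc3ccccc23)cc(OC)c1` is one of two compounds measured in a functional assay on MDA-MB-231 cells (Homo sapiens) for cytotoxicity, read by MTT assay, with a stated time of 72 h; a higher number here means a weaker inhibitor, a lower number a stronger inhibitor. In this assay compound 2 gives 16100 nM, the higher of the two numbers, and its nearest neighbour is compound 1 `FC(F)(F)c1ccc(CSc2nc(Nc3ccc(Cl)cc3)c3ccccc3n2)cc1`, which gives 15100 nM; the two lie within the scatter. Compound 3 `COc1ccc(Nc2nc(SCc3ccc(C(F)(F)F)cc3)nc3ccccc23)cc1OC` differs from compound 2 by 3,4-dimethoxyphenyl in place of 3,5-dimethoxyphenyl on a nitrogen on an aromatic ring. Among the compounds with values here, the only measured step bearing on this change, a 1.1-fold higher number from compound 1 to compound 2 (0.03 log units; within the scatter), also altered the group on that nitrogen. No step beyond the scatter is expected for compound 3 because a 1.1-fold higher number from compound 1 to compound 2 (0.03 log units; within the scatter) stayed within it, so the expected step is a 1.0-fold lower number from compound 2 to compound 3 (0.00 log units; within the scatter). Compound 3 is therefore estimated at 16000 nM, within 8000 nM to 32000 nM.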

Compound 3, half-maximal inhibitory concentration: 18900 nM
Beside the measured number, compound 3's estimate is 1.2-fold (0.07 log units) below it, and the stated range covers the measured number.
By their numbers in this assay, from the lowest: compounds 1, 2 and 3 (each within the scatter of the next).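

The change from 3,5-dimethoxyphenyl to 3,4-dimethoxyphenyl on the nitrogen gives a 1.2-fold higher number from compound 2 to compound 3 (0.07 log units; within the scatter) in this assay, and the change from 4-chlorophenyl gives a 1.3-fold higher number from compound 1 to compound 3 (0.10 log units; within the scatter). So a second dimethoxyphenyl arrangement joins the first in staying within the scatter of 4-chlorophenyl, and this assay does not tell the three groups apart at this position. No evidence is at hand on what lies behind these numbers. Going by these compounds, whether a carboxylic acid or a dimethylamino group on that phenyl ring would give a step beyond the scatter remains open.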